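The source may report more compounds than this note shows. Statements on the series, on what has been measured and on what is new or still open speak of the compounds shown alone.

Compound 3 `CCCCCCSc1nc(C(C)(C)C)ccc1CNC(=O)C(C)c1ccc(NS(C)(=O)=O)c(F)c1` gives 1.5 nM in an assay on cells for antagonist activity at transient receptor potential cation channel subfamily V member 1 (Homo sapiens), read by FLIPR and calcium flux, with a stated time of 6 min; a higher number here means a weaker inhibitor, a lower number a stronger inhibitor. Compound 1 `CCCCCCOc1nc(C(C)(C)C)ccc1CNC(=O)C(C)c1ccc(NS(C)(=O)=O)c(F)c1` gives 2.7 nM in this assay, and compound 2 `COCCCOc1nc(C(C)(C)C)ccc1CNC(=O)C(C)c1ccc(NS(C)(=O)=O)c(F)c1` gives 5.6 nM. Compound 3 thus has the lowest of the three numbers; the steps to it read a 1.8-fold lower number from compound 1 to compound 3 (0.26 log units; within the scatter) and a 3.7-fold lower number from compound 2 to compound 3 (0.57 log units; beyond the scatter). Compound 4 `CC(C(=O)NCc1ccc(C(C)(C)C)nc1SCCCN(C)C)c1ccc(NS(C)(=O)=O)c(F)c1` differs from compound 3 by dimethylamino in place of propyl on a saturated chain carbon, three bonds along the chain from a sulfur. Among the compounds with values here, the one measured step that bears on this change is a 2.1-fold higher number from compound 1 to compound 2 (0.32 log units; beyond the scatter), where methoxy replaced propyl three bonds along the chain from an oxygen on an aromatic ring. For compound 4 a step of similar modest size in the same direction is therefore expected, a 3.0-fold higher number from compound 3 to compound 4 (0.48 log units; beyond the scatter). Compound 4 is accordingly estimated at 4.5 nM, with a range from 1.5 nM to 14 nM.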

Compound 4, inhibition constant: 51.8 nM
Compound 4: middle estimate off by 12-fold (1.06 log units), on the low side; measured number outside the range, above it.
By their numbers in this assay, from the lowest: compounds 3 and 1 (each within the scatter of the next); then compound 2; then compound 4.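

Three bonds along the chain from a sulfur, dimethylamino in place of propyl gives a much larger step (a 35-fold higher number from compound 3 to compound 4 (1.54 log units; beyond the scatter)) than methoxy in place of propyl gave on the oxygen-linked chain (a 2.1-fold higher number from compound 1 to compound 2 (0.32 log units; beyond the scatter)), so that earlier step does not carry over to this change. Compound 4 also lies beyond the scatter from both oxygen-linked compounds (a 9.3-fold higher number from compound 2 to compound 4 (0.97 log units; beyond the scatter); a 19-fold higher number from compound 1 to compound 4 (1.28 log units; beyond the scatter)), including compound 2, whose chain also ends in a group other than plain alkyl. Nothing available accounts for this result.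

The compounds shown leave open whether a primary amine, a morpholine or a carboxylic acid at the same chain end would behave like dimethylamino. They also leave open whether a 3-(dimethylamino)propyl chain on oxygen would match the one on sulfur.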